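Replacing the aryl group on the amine nitrogen

This account rests on a few compounds, and the source may have more. Where it says the series, first, only, none or still open, it means among the compounds named here.

Compound 1 `CCCCCCNc1nc(SCc2ccc(C(F)(F)F)cc2)nc2ccccc12` and compound 2 `Cc1ccccc1Nc1nc(SCc2ccc(C(F)(F)F)cc2)nc2ccccc12` share one core and differ only in the group on a nitrogen on an aromatic ring. In a functional assay on HGC-27 cells (Homo sapiens) for cytotoxicity, read by MTT assay, with a stated time of 72 h (a higher number here means a weaker inhibitor, a lower number a stronger inhibitor), compound 1 gives 23900 nM, and compound 2 gives 27500 nM. Compound 2 carries the higher of these two numbers, but only by a 1.2-fold higher number from compound 1 to compound 2 (0.06 log units; within the scatter), a gap within the usual scatter of repeated measurements, so the two compounds count as equal in practice. Compound 3 `O=[N+]([O-])c1ccc(Nc2nc(SCc3ccc(C(F)(F)F)cc3)nc3ccccc23)cc1` is the next member: 4-nitrophenyl in place of 2-methylphenyl on a nitrogen on an aromatic ring. Among the compounds with values here, no measured pair shows exactly this exchange. Within the data shown here, the only step that bears on it is the one at the same nitrogen, a 1.2-fold higher number from compound 1 to compound 2 (0.06 log units; within the scatter), which barely moved the number. On that basis the exchange is expected to produce no step beyond the scatter, and the estimated step is a 1.1-fold lower number from compound 2 to compound 3 (0.02 log units; within the scatter). Compound 3 is therefore estimated at 26000 nM in this assay, with a likely range from 9000 nM to 75000 nM, the range kept wide since a nitro-bearing group has not yet been tested here.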

Compound 3, half-maximal inhibitory concentration: 16600 nM
Estimate against measurement, compound 3: 1.6-fold (0.19 log units) above, and the stated range covers the measured number.
By their numbers in this assay, from the lowest: compounds 3, 1 and 2 (each within the scatter of the next).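

In this assay, the nitrogen has now carried a hexyl chain and two different substituted phenyl groups, and the numbers stay together: a 1.7-fold lower number from compound 2 to compound 3 (0.22 log units; within the scatter) and a 1.4-fold lower number from compound 1 to compound 3 (0.16 log units; within the scatter) both lie within the usual scatter. What compound 3 adds is that 4-nitrophenyl, unlike 2-methylphenyl and hexyl, brings hydrogen-bond acceptors and a double bond outside the aromatic ring, yet no separation between the compounds appears, so among these three compounds the identity of the group on this nitrogen makes no measurable difference in this cell test. No supporting measurement is available to explain why these compounds stay so close.

The compounds shown leave open whether any group at this nitrogen can move the number beyond the scatter, since a flat result across three compounds covers only a small part of the possible groups. A phenyl ring bearing a carboxylic acid or an amine, or a chain much shorter than hexyl, would probe this position in ways that these three compounds do not.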